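A few compounds are considered here, and "the series" means these few. Any claim that something is new, unique, unknown or untested is made for them only; others in the source may bear on it.

Compound 2, `CC1(C(=O)NCCSc2nonc2/C(=N/O)Nc2ccc(F)c(C(F)F)c2)CCN1`, is the weaker of two numbers in an assay for inhibition of Indoleamine 2,3-dioxygenase 1 (Homo sapiens), read by fluorescence, with a stated time of 24 h; on this read-out higher numbers stand for weaker inhibition and lower numbers for stronger inhibition. In this assay compound 2 gives 16 nM, while compound 1, `NS(=O)(=O)CC(=O)NCCSc1nonc1/C(=N/O)Nc1cccc(Cl)c1`, gives 10 nM; the two values lie within the scatter of each other, so no order can be drawn between them. The step to compound 3, `CC(C)(O)CC(=O)NCCSc1nonc1/C(=N/O)Nc1ccc(F)c(C(F)F)c1`, changes only the tail of the amide: a group of 5 heavy atoms (4 carbon, 1 oxygen; no ring) in place of a group of 5 heavy atoms (4 carbon, 1 nitrogen; one four-membered non-aromatic ring with 1 hetero atom), on a carbonyl carbon. For the measured compounds named here, no measured pair shows such a swap, so the expected step from compound 2 to compound 3 is a 1.1-fold lower number from compound 2 to compound 3 (0.03 log units; within the scatter), not beyond the scatter. Compound 3 is estimated at 15 nM, with a range from 6 nM to 40 nM.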

Compound 3, half-maximal inhibitory concentration: 8.4 nM
Beside the measured number, compound 3's estimate is 1.8-fold (0.25 log units) above it; the range from low to high includes it.
By their numbers in this assay, from the lowest: compounds 3, 1 and 2 (each within the scatter of the next).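

In this assay, the step on this carbonyl carbon, where the 2-hydroxy-2-methylpropyl group takes the place of the group carrying a four-membered non-aromatic ring, is a 1.9-fold lower number from compound 2 to compound 3 (0.28 log units; within the scatter). For the compounds shown here, this is the first swap at this position that can be read, and it shows that the ring and its nitrogen can give way to an open chain bearing oxygen without the number moving beyond the scatter. No measurement is available that would explain this result.

Going by these compounds, it remains open whether a carboxylic acid, a primary amine or a longer carbon chain on this carbonyl carbon would also stay within the scatter. The compounds shown also leave open whether the hydroxyl oxygen matters, since no plain alkyl chain without it appears at this position.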